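The source may hold more compounds than are shown below. What is called first, only, known or untested is meant among the compounds shown, and "the series" means these compounds.

Within the data shown here, compound 1 `O=C1C(=O)N(Cc2ccc(-c3ccccc3)nc2)c2ccc(OC(F)(F)F)cc21` is the only compound with a number in a functional assay on CHO cells for positive allosteric modulation of muscarinic acetylcholine receptor M5 (Homo sapiens), read by FLIPR and calcium flux, with a stated time of 1 h (a lower number here means a smaller maximal response, a higher number a larger maximal response), where compound 1 reaches 76%. Compound 2 `O=C1C(=O)N(Cc2ccc(-c3cccnc3)cn2)c2ccc(OC(F)(F)F)cc21` has no number in this assay, where compound 2 gives "not determined" (no result reported). Compound 3 `O=C1C(=O)N(Cc2ccc(-c3cccnc3)nc2)c2ccc(OC(F)(F)F)cc21` differs from compound 1 in one place: pyridin-3-yl in place of phenyl on an aromatic carbon. Among the measured compounds shown here, with no measured step of this kind to lean on, the change is expected to be modest, either within the scatter or a small drop in maximal response. Compound 3 is estimated to reach 70%, in a range from 50% to 90%, an expected step of a number 6 percentage points lower from compound 1 to compound 3 (within the scatter).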

Compound 3, largest response reached (Emax), in percent of the reference or control that the assay uses in the muscarinic acetylcholine receptor M5 assay: 53%
Compound 3: middle estimate off by 17 percentage points, on the high side, within the range that was stated.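

In the muscarinic acetylcholine receptor M5 assay, pyridin-3-yl in place of phenyl, on a carbon next to the ring nitrogen and para to a large group, gives a number 23 percentage points lower from compound 1 to compound 3 (beyond the scatter), so the maximal response at this position is sensitive to this single change. In a physicochemical assay for lipophilicity (a higher number here means a more lipophilic compound, a lower number a more polar compound), compound 1 gives 3.6 and compound 3 gives 3, so the same change also moves the partition coefficient beyond the usual scatter.

This single pair cannot tell whether the two shifts are linked. It also leaves open how a pyridin-4-yl ring or a methoxyphenyl group would behave at this position.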